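Halogen pattern on the N-aryl ring of an amide series

The source may hold more compounds than are shown below. What is called first, only, known or untested is meant among the compounds shown, and "the series" means these compounds.

Compound 1 `Cn1ccc2c(Oc3ccc(NC(=O)c4cc5cccnc5n(-c5ccccc5)c4=O)cc3F)ccnc21` is the parent of this small set. In a functional assay on U-87MG ATCC cells for antiproliferative activity against U-87 MG (Homo sapiens), read by MTT assay, with a stated time of 72 h (a lower number here means a stronger inhibitor, a higher number a weaker inhibitor), compound 1 gives 3590 nM. Compound 2 `Cn1ccc2c(Oc3ccc(NC(=O)c4cc5cccnc5n(-c5ccc(F)cc5)c4=O)cc3F)ccnc21` carries fluoro in place of hydrogen on an aromatic carbon, and in this assay compound 2 gives 1320 nM; the step of a 2.7-fold lower number from compound 1 to compound 2 (0.43 log units; beyond the scatter) is modest but lies beyond the scatter. Compound 3 `Cn1ccc2c(Oc3ccc(NC(=O)c4cc5cccnc5n(-c5ccc(F)c(Cl)c5)c4=O)cc3F)ccnc21` was prepared as well, yet in this assay compound 3 gives "not determined" (no result reported), so compound 3 has no standing of its own on the scale set by compound 1 and compound 2. Compound 4 `Cn1ccc2c(Oc3ccc(NC(=O)c4cc5cccnc5n(-c5ccc(Br)cc5F)c4=O)cc3F)ccnc21` differs from compound 3 by 4-bromo-2-fluorophenyl in place of 3-chloro-4-fluorophenyl on an aromatic nitrogen. Among the compounds with values here, no measured step covers an exchange of this kind: the only step available, from compound 1 to compound 2, concerns a single fluoro and was modest, and the change here swaps one halogen pattern for another rather than adding to hydrogen. Without a number for compound 3, the expectation for compound 4 can only rest on compound 1 and compound 2, and no direction beyond the scatter is expected. Compound 4 is therefore estimated at 1800 nM, in a range from 600 nM to 5500 nM.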

Compound 4, half-maximal inhibitory concentration: 6470 nM
Compound 4: middle estimate off by 3.6-fold (0.56 log units), on the low side; the measured number lies above the stated range.
By their numbers in this assay, from the lowest: compound 2; then compounds 1 and 4 (each within the scatter of the next).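

In this assay, within the data shown here, 4-bromo-2-fluorophenyl in place of 4-fluorophenyl on the aromatic nitrogen gives a 4.9-fold higher number from compound 2 to compound 4 (0.69 log units; beyond the scatter), the first step at this position toward a higher number, so halogen exchange here can weaken the read-out as well as strengthen it. Against the plain phenyl of the parent, the same group gives a 1.8-fold higher number from compound 1 to compound 4 (0.26 log units; within the scatter), which lies within the scatter, so compound 4 keeps none of the gain that 4-fluorophenyl brought in compound 2, and adding halogen to this ring does not by itself lower the number. Nothing given here bears on what lies behind this reversal.

Compound 3 has no reported number, so the steps that involve it, including the exchange of 3-chloro-4-fluorophenyl for 4-bromo-2-fluorophenyl, cannot be read. The compounds shown also leave open how much of the rise belongs to the bromine and how much to the relocated fluorine, and what a phenyl ring bearing bromine alone, a methoxy group or an amine would give at this nitrogen.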